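Fluoro to Methyl: Compound 1 to Compound 4

This account rests on a few compounds, and the source may have more. Where it says the series, first, only, none or still open, it means among the compounds named here.

Compound 1 `N#C[Se]c1ccc(NC(=O)Oc2ccc(F)cc2)cc1` was tested in an ADME assay on 184B5 cells (Homo sapiens) for cytotoxicity, read by MTT assay, with a stated time of 72 h (a lower number here means a stronger inhibitor of growth, a higher number a weaker inhibitor of growth), where compound 1 gives 6900 nM. Among the three measured compounds, compound 1 has the highest number, but compound 2 `N#C[Se]c1ccc(NC(=O)OCc2ccccc2)cc1` gives 5000 nM and compound 3 `O=C(Nc1ccc([Se][Se]c2ccc(NC(=O)Oc3ccccc3)cc2)cc1)Oc1ccccc1` gives 4500 nM, and both of these sit within the scatter of compound 1, so no ranking of the three can be drawn. Compound 4 `Cc1ccc(OC(=O)Nc2ccc([Se]C#N)cc2)cc1` has not yet been measured. It differs from compound 1 in one place: methyl in place of fluoro on an aromatic carbon. No measured pair that differs in one place is available, so the size of this step cannot be anchored on shown data; the three measured values all lie close together, and the exchange of one group for another gives no grounds to expect a step beyond the scatter in either direction. Compound 4 is therefore expected to give about 6000 nM in this assay, with a range from 2500 nM to 14000 nM, an estimated step of a 1.2-fold lower number from compound 1 to compound 4 (0.06 log units; within the scatter) that is expected to stay within the scatter.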

Compound 4, concentration for 50% growth inhibition: 4400 nM
For compound 4 the middle estimate is 1.4-fold (0.13 log units) above the measured one; low and high end bracket the measured number.
By their numbers in this assay, from the lowest: compounds 4, 3, 2 and 1 (each within the scatter of the next).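

Methyl in place of fluoro on an aromatic carbon, para to a large group, gives the first step here that can be read at a single place: in this assay it amounts to a 1.6-fold lower number from compound 1 to compound 4 (0.20 log units; within the scatter). Among these compounds, at this position, then, the two groups are not told apart by this read-out, and the exchange gives no ranking of the pair. No measurement on any property of either group bears on this result, so the data offer no explanation for it.

Going by these compounds, whether an amine, a carboxylic acid or a longer chain at this position would give a step beyond the scatter remains open. So does whether methyl in place of fluoro would give a similar step elsewhere on the ring or on a different core.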